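A few compounds are considered here, and "the series" means these few. Any claim that something is new, unique, unknown or untested is made for them only; others in the source may bear on it.

Compound 1 `O=C(Nc1ccc(C(F)(F)F)cc1)c1cc(Cl)c(-c2ccccc2)cc1O` in a functional assay on NALM-6 cells (Homo sapiens) for cytotoxicity, read by luminescence and CellTiter-Glo, with a stated time of 3 days (on this read-out lower numbers stand for stronger inhibition and higher numbers for weaker inhibition), gives 800 nM. Compound 3 `O=C(Nc1ccc(C(F)(F)F)cc1)c1cc(Br)c(-c2ccccc2)cc1O` differs from it in one place, (bromo in place of chloro on an aromatic carbon), and in this assay compound 3 gives 1000 nM, a step of a 1.3-fold higher number from compound 1 to compound 3 (0.10 log units; within the scatter). Compound 2 `O=C(Nc1ccc(Cl)c(Cl)c1)c1cc(F)ccc1O` carries a different core; the difference between the two cores is not broken down here. In this assay compound 2 gives 1370 nM; its value lies within the scatter of that of compound 3 and also within that of compound 1.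

Compound 4 `O=C(Nc1ccc(Br)c(Cl)c1)c1cc(F)ccc1O` is not yet measured. It relates to compound 2 as compound 3 relates to compound 1: bromo in place of chloro on an aromatic carbon. The surroundings are not the same: in compound 1 the site is ortho to a phenyl group (6 heavy atoms), meta to a large group and para to a hydroxy group (1 heavy atom), whereas in compound 2 it is ortho to a chloro group (1 heavy atom) and para to a large group, so this is the same kind of change, not the same change. Among the measured compounds shown here, a similarly small step in this assay is expected, a 1.2-fold higher number from compound 2 to compound 4 (0.07 log units; within the scatter), because a 1.3-fold higher number from compound 1 to compound 3 (0.10 log units; within the scatter) is the only measured example of this kind of change and stayed within the scatter. Compound 4 is therefore expected to give about 1600 nM, between 800 nM and 3200 nM, resting on a single precedent.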

Compound 4, half-maximal inhibitory concentration: 1250 nM
The estimate for compound 4 lay 1.3-fold (0.11 log units) above the measured number; measured number inside the range.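

In this assay, bromo in place of chloro on an aromatic carbon gives a 1.1-fold lower number from compound 2 to compound 4 (0.04 log units; within the scatter), so on the core of compound 2 this change stays within the scatter. Set beside the same change on the core of compound 1, the two steps do not differ: the same change on two cores in this assay, a 1.3-fold higher number (0.10 log units; within the scatter) from compound 1 to compound 3 and a 1.1-fold lower number (0.04 log units; within the scatter) from compound 2 to compound 4, 1.4-fold (0.14 log units) apart, within the scatter of two such steps. This shows that the change stayed small on two cores in this one cell read-out, at sites with different surroundings, but two small steps give no rule for other cores or other sites and do not explain why the numbers hold.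

The compounds shown leave open whether a group other than a halogen at this site, such as a nitrile, a methoxy group or an amine, would move the number beyond the scatter. Also open, from the compounds shown here alone, is what a carboxylic acid in place of the hydroxy group would do on either core.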